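The source may hold more compounds than are shown below. What is called first, only, known or untested is meant among the compounds shown, and "the series" means these compounds.

Compound 1, `COC(=O)Nc1nc2cc(C(=O)NC(C)C)ccc2[nH]1`: in a functional assay on L1210 cells (Mus musculus) for inhibition (a lower number here means a stronger inhibitor, a higher number a weaker inhibitor), compound 1 gives 2000 nM.
Compound 2, `C=CCOC(=O)c1ccc2[nH]c(NC(=O)OC)nc2c1`: compound 2 gives only a limit, > 10000 nM, in this assay.

Among the measured compounds shown here, compound 2 thus stands at the limit of > 10000 nM in this assay, at which 1 of the 2 values shown sits, and of the two measured compounds it is the one for which no number is known. For the measured compounds named here, the single measured step, an at least 5.0-fold higher number from compound 1 to compound 2 (0.69 log units; beyond the scatter), put allyloxy in place of isopropylamino on a carbonyl carbon and carried compound 2 to that limit. Compound 3, `COC(=O)Nc1nc2cc(C(=O)OCC3CC3)ccc2[nH]1`, differs from compound 2 by cyclopropyl in place of vinyl on a saturated chain carbon bound to an oxygen next to a carbonyl group. Going by the values given here, no measured step concerns a change of this kind, so the only guide is the limit at which compound 2 sits. The step from compound 2 to compound 3 is therefore expected to stay within the scatter, a step that the limit leaves unreadable from compound 2 to compound 3. Compound 3 is accordingly expected to give about 15000 nM in this assay, with a range from 5000 nM to 50000 nM, most likely again reported only as a limit.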

Compound 3, half-maximal inhibitory concentration: 6900 nM
The estimate for compound 3 lay 2.2-fold (0.34 log units) above the measured number, within the range that was stated.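

Compound 3 gives the cyclopropylmethoxy carbonyl compound a measured number in this assay, so replacing the isopropylamino group on this carbonyl carbon does not always take the value to the limit of the assay. The replacement of isopropylamino by cyclopropylmethoxy now has a definite size, a 3.5-fold higher number from compound 1 to compound 3 (0.54 log units; beyond the scatter), and it runs in the same direction as the replacement by allyloxy. The change from vinyl to cyclopropyl gives an at least 1.4-fold lower number from compound 2 to compound 3 (0.16 log units; that floor lies within the scatter), and its true size cannot be read because compound 2 is known only as a limit: the limit of > 10000 nM in this assay, at which 1 of the 3 values shown sits.

The compounds shown leave open how a carboxylic acid or a longer chain on the oxygen would read in this assay. They also leave open whether any other amine on this carbonyl carbon would give a lower number than compound 1.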